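A Fluoronaphthyl Swap Tested for Cell Toxicity

A few compounds are considered here, and "the series" means these few. Any claim that something is new, unique, unknown or untested is made for them only; others in the source may bear on it.

Compound 2 `Cc1cc(S(N)(=O)=O)ccc1NC(=O)COc1ccc(F)cc1Oc1ccc2ccccc2c1Br` was tested in an ADME assay on C8166 cells (Homo sapiens) for cytotoxicity, read by MTT assay (on this read-out higher numbers stand for lower toxicity in this test and lower numbers for higher toxicity in this test), where compound 2 gives 39500 nM. Compound 1 `Cc1cc(S(N)(=O)=O)ccc1NC(=O)COc1ccc(F)cc1Oc1cccc2ccccc12` differs only in its naphthalene group; in this assay compound 1 gives 33100 nM, and the step between them is a 1.2-fold higher number from compound 1 to compound 2 (0.08 log units; within the scatter), so the two numbers cannot be told apart. Compound 3 `Cc1cc(S(N)(=O)=O)ccc1NC(=O)COc1ccc(F)cc1Oc1ccc2cccc(F)c2c1` is not yet measured; it carries 8-fluoronaphthalen-2-yl in place of 1-bromonaphthalen-2-yl on an oxygen on an aromatic ring. Going by the values given here, the one measured step at this position, a 1.2-fold higher number from compound 1 to compound 2 (0.08 log units; within the scatter), hardly moved the number, so the coming change is expected to be a 1.1-fold lower number from compound 2 to compound 3 (0.04 log units; within the scatter), nothing beyond the scatter. Compound 3 is therefore estimated at 36000 nM, between 15000 nM and 85000 nM.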

Compound 3, half-maximal cytotoxic concentration: 171000 nM
Compound 3: middle estimate off by 4.8-fold (0.68 log units), on the low side; the measured number lies above the stated range.
By their numbers in this assay, from the lowest: compounds 1 and 2 (each within the scatter of the next); then compound 3.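

The group on the oxygen can move the number after all: 8-fluoronaphthalen-2-yl gives a 4.3-fold higher number from compound 2 to compound 3 (0.64 log units; beyond the scatter) and also a 5.2-fold higher number from compound 1 to compound 3 (0.71 log units; beyond the scatter) in this assay and so reads as lower toxicity in this test. The earlier step between two naphthalene groups stayed within the scatter and gave no sign of this. Nothing measured here explains the shift.

The fluorine and the point where the naphthalene joins the oxygen both differ, so their shares stay unresolved. A plain naphthalen-2-yl, or an amine on the naphthalene, remains an open comparison.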